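Shifting the methoxy on the ring of compound 3

A few compounds are considered here, and "the series" means these few. Any claim that something is new, unique, unknown or untested is made for them only; others in the source may bear on it.

Within the data shown here, compound 3 `COc1ccccc1/C=C/c1nc(N2CCC(CCNS(N)(=O)=O)CC2)c2cc(OC)c(OC)cc2n1` sits at the top of the three numbers so far: in an assay on cells for inhibition of Ectonucleotide pyrophosphatase/phosphodiesterase family member 1 (Homo sapiens), with a stated time of 60 min, tested at 1 uM (on this read-out lower numbers stand for less inhibition and higher numbers for more inhibition at the one concentration tested (going by the name of the read-out)), compound 3 gives 74%. Compound 2 `COc1cc2nc(/C=C/c3ccc(F)cc3)nc(N3CCC(CCNS(N)(=O)=O)CC3)c2cc1OC` gives 70%, and compound 1 `COc1cc2nc(/C=C/c3ccccc3)nc(N3CCC(CCNS(N)(=O)=O)CC3)c2cc1OC` gives 33%. The gap between compound 2 and compound 3 stays within the scatter, a number 4 percentage points higher from compound 2 to compound 3 (within the scatter), so these two cannot be ordered; only compound 1 falls clearly away, a number 41 percentage points higher from compound 1 to compound 3 (beyond the scatter).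

Compound 4 `COc1cccc(/C=C/c2nc(N3CCC(CCNS(N)(=O)=O)CC3)c3cc(OC)c(OC)cc3n2)c1` is reached from compound 3 by 3-methoxyphenyl in place of 2-methoxyphenyl on a double-bonded chain carbon bound to a double-bonded chain carbon. Among the measured compounds shown here, no measured step moves a methoxy from one aromatic carbon to another, so the change has no direct precedent here. What does bear on it are the two substitutions of hydrogen on an aromatic carbon: a number 37 percentage points higher from compound 1 to compound 2 (beyond the scatter) and a number 41 percentage points higher from compound 1 to compound 3 (beyond the scatter). Both compounds carrying a group on that ring sit close together, and the exchange of one such group for the other, a number 4 percentage points higher from compound 2 to compound 3 (within the scatter), stays within the scatter. The expectation is therefore that compound 4 behaves like compound 2 and compound 3 rather than like compound 1, and compound 4 is estimated to give 65% (range 45% to 85%). The expected step is a number 9 percentage points lower from compound 3 to compound 4 (within the scatter), a small drop that is expected to stay within the scatter.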

Compound 4, a percentage reported as inhibition, at one concentration (the size of the read-out at that concentration, not a potency): 88%
Compound 4: middle estimate off by 23 percentage points, on the low side; measured number outside the range, above it.
By their numbers in this assay, from the lowest: compound 1; then compounds 2 and 3 (each within the scatter of the next); then compound 4.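

In this assay, among these compounds, where the methoxy sits on the ring counts: with the same atoms joined differently, 3-methoxyphenyl in place of 2-methoxyphenyl gives a number 14 percentage points higher from compound 3 to compound 4 (beyond the scatter) and so separates two compounds that differ only in that placement, something the earlier compounds could not show. Compound 2 and compound 3 could not be ordered, yet 3-methoxyphenyl in place of 4-fluorophenyl gives a number 18 percentage points higher from compound 2 to compound 4 (beyond the scatter) and methoxy in place of hydrogen on an aromatic carbon now gives a number 55 percentage points higher from compound 1 to compound 4 (beyond the scatter) as its largest step in the series, so a group on that ring is not interchangeable with any other and compound 4 stands clear of the other three. Nothing at hand explains why the 3-methoxyphenyl group stands apart.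

Still open, from the compounds shown here alone, is whether a hydroxy, an amine or a carboxylic acid in place of the methoxy of the 3-methoxyphenyl group would hold this level of inhibition, or whether the methoxy itself is needed there. Also open, going by these compounds, is whether the order seen in this assay carries over to potency, as a read-out at one concentration gives only the size of the effect at that concentration.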